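Chloro Added to a Compound That Showed No Effect

A few compounds are considered here, and "the series" means these few. Any claim that something is new, unique, unknown or untested is made for them only; others in the source may bear on it.

Compound 1, `Cc1nnc(CN(C)C)n1-c1ccccc1C(=O)c1ccccc1Cl`: > 100 mg/kg
Compound 2, `CNCc1nnc(C)n1-c1ccc(Cl)cc1C(=O)c1ccccc1`: 2 mg/kg

In a functional assay on the whole organism (strain CF-1) for positive allosteric modulation, with Mus musculus as the target (a higher number here means that more compound is needed for the effect, a lower number that less compound is needed), compound 1 gives > 100 mg/kg, and this is a limit of the measurement rather than a number, as the limit of > 100 mg/kg in this assay, at which 1 of the 2 values shown sits, records. Compound 2 reaches 2 mg/kg in this assay. Compound 2 differs from compound 1 in more than one place, so the two values show only that they lie far apart and do not isolate any single change.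

Compound 3, `Cc1nnc(CN(C)C)n1-c1ccc(Cl)cc1C(=O)c1ccccc1Cl`, has not been measured. It differs from compound 1 by chloro in place of hydrogen on an aromatic carbon. For the measured compounds named here, no measured pair isolates this change. Compound 2 also carries a chloro on the same ring, which is the only hint available. The step from compound 1 to compound 3 is expected to be an at least 3.3-fold lower number from compound 1 to compound 3 (0.52 log units; beyond the scatter) in this assay, towards less compound needed, with wide uncertainty. Compound 3 is therefore estimated at 30 mg/kg, with a range from 5 mg/kg to 200 mg/kg.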

Compound 3, dose for half-maximal effect: 0.63 mg/kg
Beside the measured number, compound 3's estimate is 48-fold (1.68 log units) above it; measured number below the stated range.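

In this assay, chloro in place of hydrogen on this aromatic carbon gives an at least 150-fold lower number from compound 1 to compound 3 (2.20 log units; beyond the scatter). The earlier pair differed in more than one place, whereas this pair differs in one, so the gap can be tied to a chloro at this position, para to a large group and meta to a group of 9 heavy atoms. Compound 1 gives > 100 mg/kg, which is a limit and not a number, so the full size of the step stays unknown: the limit of > 100 mg/kg in this assay, at which 1 of the 3 values shown sits.

The compounds shown do not tell whether fluoro, bromo, methyl or a nitrile at this position would do the same as chloro. They also leave open whether a chloro on another carbon of this ring would bring a similar step.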